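A few compounds are considered here, and "the series" means these few. Any claim that something is new, unique, unknown or untested is made for them only; others in the source may bear on it.

Values in a functional assay on PC-3 cells (Homo sapiens) for cytotoxicity, read by MTT assay, with a stated time of 96 h; a higher number here means a weaker inhibitor, a lower number a stronger inhibitor:
- Compound 1 `CC[C@H](N)C(=O)N[C@@H]1C(=O)N2[C@@H](CC[C@@H]1CNC(=O)NCc1ccccc1)CC[C@H]2C(=O)NC(c1ccccc1)c1ccccc1`: > 100000 nM, a limit
- Compound 2 `CC[C@H](N)C(=O)N[C@@H]1C(=O)N2[C@@H](CC[C@@H]1CCNC(=O)c1ccccc1)CC[C@H]2C(=O)NC(c1ccccc1)c1ccccc1`: > 100000 nM, a limit
- Compound 3 `CCNCC[C@H]1CC[C@H]2CC[C@@H](C(=O)NC(c3ccccc3)c3ccccc3)N2C(=O)[C@H]1NC(=O)[C@@H](N)CC`: > 100000 nM, a limit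

Compound 3 has no number of its own, only the limit > 100000 nM. It cannot be ranked against the other two compounds, and the whole set comes down to one finding: the limit of > 100000 nM in this assay, at which 3 of the 3 values shown sit.

Compound 4 `CC[C@H](N)C(=O)N[C@@H]1C(=O)N2[C@@H](CC[C@@H]1CCNCc1ccccc1)CC[C@H]2C(=O)NC(c1ccccc1)c1ccccc1` carries phenyl in place of methyl on a saturated chain carbon bound to an amine nitrogen, so that ethylamino becomes benzylamino: phenyl in place of methyl on a saturated chain carbon bound to an amine nitrogen.

Among the measured compounds shown here, three measured steps bear on this change: a step that the two limits leave unreadable from compound 2 to compound 3, a step that the two limits leave unreadable from compound 1 to compound 3 and a step that the two limits leave unreadable from compound 1 to compound 2. None of them has a size that can be read, so they give no direction and no size to carry over. The three side chains tried so far all end at the same limit, and a similar outcome is therefore expected in this assay, with no readable step. The estimated change is a number no higher from compound 3 to compound 4 (the limit leaves the size open). Compound 4 is expected at about 100000 nM, with an estimated range of 40000 nM to 200000 nM.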

Compound 4, half-maximal inhibitory concentration: 39200 nM
For compound 4 the middle estimate is 2.6-fold (0.41 log units) above the measured one; the whole stated range lies above it.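

The steps among compound 1, compound 2 and compound 3 cannot be read, and only compound 4 carries a number rather than a limit in this assay: the limit of > 100000 nM in this assay, at which 3 of the 4 values shown sit.

Phenyl in place of methyl on a saturated chain carbon bound to an amine nitrogen gives an at least 2.5-fold lower number from compound 3 to compound 4 (0.40 log units; beyond the scatter), the first step in this set with a readable direction. The same direction appears in an at least 2.5-fold lower number from compound 2 to compound 4 (0.40 log units; beyond the scatter), and (benzylamino)methyl in place of (benzylcarbamoyl)amino gives an at least 2.5-fold lower number from compound 1 to compound 4 (0.40 log units; beyond the scatter), so a phenyl ring in the side chain does not alone set compound 4 apart, as compound 1 and compound 2 also carry one.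

The compounds shown leave open whether a phenethyl group or a substituted benzyl on the amine nitrogen would lower the number further. They also leave open whether a tertiary amine would hold the value of compound 4, 39200 nM.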